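This account rests on a few compounds, and the source may have more. Where it says the series, first, only, none or still open, it means among the compounds named here.

For the measured compounds named here, compound 3 `C[C@@H](CF)OC(=O)N1CCC(O[C@H]2CC[C@H](Oc3cnc(S(C)(=O)=O)cn3)CC2)CC1` gives 105% in a functional assay on isolated protein for agonist activity at Glucose-dependent insulinotropic receptor (Homo sapiens), read by HTRF and cAMP accumulation (on this read-out higher numbers stand for larger maximal responses and lower numbers for smaller maximal responses), the second highest of the three numbers known so far. Compound 1 `CC(C)(C)OC(=O)N1CCC(O[C@H]2CC[C@H](Oc3ccc(S(C)(=O)=O)nn3)CC2)CC1` gives 97%, within the scatter of compound 3, while compound 2 `CC1(OC(=O)N2CCC(O[C@H]3CC[C@H](Oc4cnc(S(C)(=O)=O)cn4)CC3)CC2)CC1` gives 118%, beyond it. Compound 4 `CS(=O)(=O)c1cnc(O[C@H]2CC[C@H](OC3CCN(C(=O)C4(C(F)(F)F)CCCC4)CC3)CC2)cn1` differs from compound 3 in one place: a group of 9 heavy atoms (6 carbon, 3 fluorine; one five-membered non-aromatic ring of carbon only) in place of a group of 5 heavy atoms (3 carbon, 1 oxygen, 1 fluorine; no ring), on a carbonyl carbon. Going by the values given here, the only step measured in this region, a number 13 percentage points lower from compound 2 to compound 3 (beyond the scatter), exchanged the group on the oxygen; the change to compound 4 instead removes that oxygen-bearing group altogether on the carbonyl carbon, so no measured step matches it closely. With all three numbers near the reference, a modest step at most is expected. Compound 4 is estimated at 100% in this assay, range 80% to 120%. The expected step is a number 5 percentage points lower from compound 3 to compound 4 (within the scatter).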

Compound 4, largest response reached (Emax), in percent of the reference or control that the assay uses: 95%
For compound 4 the middle estimate is 5 percentage points above the measured one; measured number inside the range.
By their numbers in this assay, from the lowest: compounds 4, 1 and 3 (each within the scatter of the next); then compound 2.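

Exchanging the oxygen-bearing group on the carbonyl carbon for the fluorinated group with a five-membered carbon ring keeps the response in this assay level with compound 3 (a number 10 percentage points lower from compound 3 to compound 4 (within the scatter)). The same exchange starting from the 1-methylcyclopropyl group gives a step that does register (a number 23 percentage points lower from compound 2 to compound 4 (beyond the scatter)), so groups at this place can still be told apart. Nothing available explains either step.

Open, from the compounds shown here alone, is how an amine on the carbonyl carbon would compare. The ring and the fluorines enter together, so their separate contributions remain unresolved.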